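The compounds below may be only part of what the source reports. "The series", "measured", "known", "first", "only" and "open" are said of these compounds alone.

Three compounds from the study have been examined in a functional assay on NCI-H460 cells (Homo sapiens) for antiproliferative activity, read by CCK-8 assay, with a stated time of 72 h, tested at 2 uM; a higher number here means a stronger effect of the compound at the concentration tested, a lower number a weaker effect. Compound 1, `COC(CCn1cnc2c(NCc3ccc(C(=O)Nc4ccccc4N)cc3)nc(Cl)nc21)OC`, gives 43.7% in this assay. Compound 2, `Nc1ccccc1NC(=O)c1ccc(Cn2cnc3c(Nc4ccccc4)nc(Cl)nc32)cc1`, gives 42.7%. Compound 3, `CC(C)n1cnc2c(Nc3cccc(Cl)c3)nc(NCOCc3ccc(/C=C/C(=O)Nc4ccccc4N)cc3)nc21`, gives 53%. Compound 2 has the lowest of the three numbers, but its nearest neighbour, compound 1, sits within the usual scatter of such measurements, so the two cannot be told apart; only compound 3 lies beyond the scatter, and compound 3 shows the higher number of that pair.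

The account now turns to compound 4, `Nc1ccccc1NC(=O)c1ccc(Cn2cnc3c(Nc4cccc(Cl)c4)nc(Cl)nc32)cc1`, which has not yet been measured in this assay. It differs from compound 2 in a single place: chloro in place of hydrogen on an aromatic carbon. For the measured compounds named here, no pair of measured compounds shows this change on its own, so nothing in the data sets its size. Compound 3 also carries a chloro group on that ring, but it differs from compound 2 in several other places as well, so its higher number cannot be assigned to the chloro group.

The expectation is therefore a step of no clear direction, lying within the scatter: a number 3.3 percentage points higher from compound 2 to compound 4 (within the scatter). Compound 4 is thus estimated to give 46% in this assay, with a plausible range from 34% to 59%.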

Compound 4, a percentage reported as inhibition, at one concentration (the size of the read-out at that concentration, not a potency): 10.3%
The estimate for compound 4 lay 35.7 percentage points above the measured number, and the stated range ends above it.
By their numbers in this assay, from the lowest: compound 4; then compounds 2, 1 and 3 (each within the scatter of the next, the first and the last beyond it).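

In this assay, for the compounds shown here, the single change from phenyl to 3-chlorophenyl, or anilino to (3-chlorophenyl)amino, proves far from silent: the step is a number 32.4 percentage points lower from compound 2 to compound 4 (beyond the scatter) and it is the first step between measured compounds that differ in one place. The earlier compounds shown here included no such pair, so they could not show that this aromatic carbon, meta to a large group, is a place where one added chlorine atom takes away most of the read-out at the concentration tested. Nothing in the material shown bears on why the number falls.

The compounds shown leave open whether this fall belongs to chloro itself or would also follow a fluoro, methyl or methoxy group at the same carbon. They also leave open whether chloro on another carbon of this ring, or the same change with the chloro on the core replaced by an amine, would give a step of this size.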